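The compounds below may be only part of what the source reports. "The series", "measured", "known", "first", "only" and "open" are said of these compounds alone.

Of the compounds shown here, three sharing one core have so far been measured in a functional assay on HeLa cells (Homo sapiens) for antiproliferative activity, read by sulforhodamine B assay, with a stated time of 48 h; on this read-out higher numbers stand for weaker inhibition of growth and lower numbers for stronger inhibition of growth. Compound 1 `O=C(NCc1cn(Cc2ccc(C(F)(F)F)cc2)nn1)c1cn(-c2ccccc2)nc1-c1ccc(F)cc1` gives 250 nM. Compound 2 `COc1cc(Cn2cc(CNC(=O)c3cn(-c4ccccc4)nc3-c3ccc(F)cc3)nn2)cc(OC)c1` gives 360 nM, the second highest of the three numbers. Compound 3 `COc1cc(Cn2cc(CNC(=O)c3cn(-c4ccccc4)nc3-c3ccc(F)cc3)nn2)cc(OC)c1OC` gives 2100 nM. Of the steps between them, a 1.4-fold higher number from compound 1 to compound 2 (0.16 log units; within the scatter) is within the scatter, whereas an 8.4-fold higher number from compound 1 to compound 3 (0.92 log units; beyond the scatter) and a 5.8-fold higher number from compound 2 to compound 3 (0.77 log units; beyond the scatter) are both beyond it. Compound 4 `COc1cc(Cn2cc(CNC(=O)c3cn(-c4ccccc4)nc3-c3ccc(Cl)cc3)nn2)cc(OC)c1` has not yet been measured. It differs from compound 2 by chloro in place of fluoro on an aromatic carbon. Going by the values given here, none of the measured steps bears on this change: all three concern the group on the saturated chain carbon bound to an aromatic nitrogen, while the 4-fluorophenyl is kept unchanged throughout the measured set. Among the compounds with values here, with no measured step to draw on, the step of a 1.1-fold higher number from compound 2 to compound 4 (0.05 log units; within the scatter) is expected to stay within the scatter, in no set direction. Compound 4 is therefore estimated at 400 nM, with a range from 150 nM to 1100 nM.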

Compound 4, concentration for 50% growth inhibition: 730 nM
Estimate against measurement, compound 4: 1.8-fold (0.26 log units) below; measured number inside the range.
By their numbers in this assay, from the lowest: compounds 1 and 2 (each within the scatter of the next); then compound 4; then compound 3.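

In this assay, going by these compounds alone, the change from 4-fluorophenyl to 4-chlorophenyl gives a 2.0-fold higher number from compound 2 to compound 4 (0.31 log units; beyond the scatter), the first measured step at this position, where every earlier compound carried the 4-fluorophenyl. The step is modest but lies just beyond the scatter, so this place on the aromatic ring, para to a large group, is not indifferent to which halogen it carries, at least with the 3,5-dimethoxyphenyl group held fixed. No evidence is available on what lies behind this step.

On these data alone, the change is seen in this one pair only, so it remains open whether it would run the same way with the 4-(trifluoromethyl)phenyl of compound 1 or the 3,4,5-trimethoxyphenyl of compound 3. Also open, as far as these compounds go, is how hydrogen, a methoxy group or an amine would read at this same place.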